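A few compounds are considered here, and "the series" means these few. Any claim that something is new, unique, unknown or untested is made for them only; others in the source may bear on it.

Measured so far in a functional assay on NALM-6 cells (Homo sapiens) for cytotoxicity, read by MTT assay, with a stated time of 48 h; a higher number here means a weaker inhibitor, a lower number a stronger inhibitor:

compound 1, `C=C1C(=O)OC(C)CC1c1ccc(Br)cc1`: compound 1 gives 4510 nM
compound 2, `C=C1C(=O)OC(C)CC1c1ccc(OC)cc1`: compound 2 gives 5760 nM
compound 3, `C=C1C(=O)O[C@H](C)[C@@H]1c1ccc(Br)cc1`: compound 3 gives 4250 nM

Compound 2 differs from compound 1 by one change, (methoxy in place of bromo on an aromatic carbon); the step is a 1.3-fold higher number from compound 1 to compound 2 (0.11 log units; within the scatter). Compound 3 shares the same substituent pattern as compound 1 on a different core; how the two cores differ is not broken down here, and their two values in this assay lie within the scatter of each other.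

Compound 4, `C=C1C(=O)O[C@H](C)[C@@H]1c1ccc(OC)cc1`, is not yet measured. It stands to compound 3 as compound 2 stands to compound 1: methoxy in place of bromo on an aromatic carbon. The change is the same kind of change, not the same, since around the place the group para to the aromatic carbon has 8 heavy atoms in compound 3, whereas in compound 1 the group para to the aromatic carbon has 9 heavy atoms.

Among the measured compounds shown here, the only precedent is the step from compound 1 to compound 2, which stayed within the scatter; the expectation is a step of the same size, a 1.3-fold higher number from compound 3 to compound 4 (0.11 log units; within the scatter), resting on a 1.3-fold higher number from compound 1 to compound 2 (0.11 log units; within the scatter). Compound 4 is therefore estimated at 5500 nM in this assay, with a range from 3300 nM to 9500 nM expected.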

Compound 4, half-maximal inhibitory concentration: 5590 nM
Compound 4: middle estimate off by 1.0-fold (0.01 log units), on the low side; the measured number falls inside the stated range.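

In this assay, methoxy in place of bromo on the aromatic carbon gives a 1.3-fold higher number from compound 3 to compound 4 (0.12 log units; within the scatter). The change carries from one core to the other with a step of matching size: the same change on two cores in this assay, a 1.3-fold higher number (0.11 log units; within the scatter) from compound 1 to compound 2 and a 1.3-fold higher number (0.12 log units; within the scatter) from compound 3 to compound 4, 1.0-fold (0.01 log units) apart, within the scatter of two such steps. Among the compounds shown here, this shows only that two small steps agree on this pair of cores; since both lie within the scatter, it does not show that the change has a real effect on either core, or that a step beyond the scatter would carry over in the same way.

The compounds shown hold only bromo and methoxy at this place, so an amine, a carboxylic acid or a longer alkoxy chain there remains open. Also open, as far as these compounds go, is how any such group would behave on each of the two cores.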